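This account rests on a few compounds, and the source may have more. Where it says the series, first, only, none or still open, it means among the compounds named here.

Measured so far:
compound 1, `Cc1ccc(C(=O)Nc2sc3c(c2C(N)=O)CCOC3)s1`: 778 nM
compound 2, `CC1(C)Cc2c(sc(NC(=O)c3ccccc3O)c2C(N)=O)CO1`: 13 nM
compound 3, `CC1(C)Cc2c(sc(NC(=O)C3CCNC3=O)c2C(N)=O)C(C)(C)O1`: 101 nM

These three compounds were tested in an assay on cells for positive allosteric modulation of Cystic fibrosis transmembrane conductance regulator variant F508del (Homo sapiens), with stated times of 10 min and 7 s, in the presence of a further agent that is not named here; a higher number here means that more compound is needed for the effect, a lower number that less compound is needed. Compound 3 stands second highest of the three numbers, with 101 nM. Its nearest neighbour is compound 1 at 778 nM, a higher number that lies beyond the scatter. Furthest from it is compound 2 at 13 nM, a lower number, also beyond the scatter. Among the measured compounds shown here, no step between two measured compounds differing in a single place is given, so each pair can only be read from its two values as they stand.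

The step under study leads from compound 3 to compound 4, `CC1(C)Cc2c(sc(NC(=O)c3cc(C(F)(F)F)n[nH]3)c2C(N)=O)C(C)(C)O1`, which has not yet been measured in this assay. The structural change is 3-(trifluoromethyl)-1H-pyrazol-5-yl in place of 2-oxopyrrolidin-3-yl on a carbonyl carbon.

For the measured compounds named here, since no single-place step is available, the direction can only be inferred loosely. Compound 4 is expected to give a lower number than compound 3, estimated as a step of a 3.4-fold lower number from compound 3 to compound 4 (0.53 log units; beyond the scatter), a moderate improvement that is judged plausible because compound 2 gives 13 nM on a related scaffold. The estimate for compound 4 is 30 nM, with a range from 8 nM to 120 nM.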

Compound 4, half-maximal effective concentration: 3 nM
Compound 4: middle estimate off by 10-fold (1.00 log units), on the high side; the measured number lies below the stated range.
By their numbers in this assay, from the lowest: compound 4; then compound 2; then compound 3; then compound 1.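

In this assay, putting 3-(trifluoromethyl)-1H-pyrazol-5-yl in place of 2-oxopyrrolidin-3-yl on a carbonyl carbon whose other neighbours are an amide-type nitrogen gives a 34-fold lower number from compound 3 to compound 4 (1.53 log units; beyond the scatter) and leaves the rest of the structure unchanged. Among the compounds shown here, the earlier compounds differ from one another in more than one place, so this is the first reading that ties a large change in the number to the group at this position alone. Both groups are five-membered rings with the same counts of hydrogen-bond donors and acceptors, so those counts do not separate them, while the aromatic ring, the second ring nitrogen and the three fluorine atoms enter together, and no measurement shown explains why the number moves so far.

Going by these compounds, it remains open how much of the step belongs to the trifluoromethyl group and how much to the pyrazole ring, and how a methyl group or a chlorine atom at that place on the same ring would read. On these data alone, compound 1 and compound 2 differ from compound 4 in more than one place, so how the entering group would behave on their cores also stays open.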